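Swapping the Benzyl Group on a Triazole-Linked Amide

A few compounds are considered here, and "the series" means these few. Any claim that something is new, unique, unknown or untested is made for them only; others in the source may bear on it.

Among the measured compounds shown here, compound 1 `Cc1cc(C)c(Oc2cc(Nc3ccc(C#N)cc3)ncc2C(=O)NCc2cn(Cc3cccc(Cl)c3)nn2)c(C)c1` stands highest of the two numbers measured so far in an ADME assay on MT4 cells (Homo sapiens) for cytotoxicity, read by MTT assay, with a stated time of 5 days; a lower number here means that less compound is tolerated, a higher number that more compound is tolerated; in that test compound 1 gives 187000 nM. Its nearest neighbour is compound 2 `CCOC(=O)CCn1cc(CNC(=O)c2cnc(Nc3ccc(C#N)cc3)cc2Oc2c(C)cc(C)cc2C)nn1`, which in this assay gives 21500 nM. For the measured compounds named here, the single change between them, (ethoxycarbonyl)methyl in place of 3-chlorophenyl on a saturated chain carbon bound to an aromatic nitrogen, goes with a step of an 8.7-fold lower number from compound 1 to compound 2 (0.94 log units; beyond the scatter).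

Compound 3 `Cc1cc(C)c(Oc2cc(Nc3ccc(C#N)cc3)ncc2C(=O)NCc2cn(Cc3ccc([N+](=O)[O-])cc3)nn2)c(C)c1` has not yet been measured. It differs from compound 1 in one place: 4-nitrophenyl in place of 3-chlorophenyl on a saturated chain carbon bound to an aromatic nitrogen. Going by the values given here, the only measured step that touches this place is the one from compound 1 to compound 2, and it brings in a different group, so it shows only that a change here can move the number beyond the scatter, as seen in an 8.7-fold lower number from compound 1 to compound 2 (0.94 log units; beyond the scatter). With one aromatic ring leaving and another entering, a smaller shift is anticipated. Compound 3 is therefore expected to give 110000 nM in this assay, with a range from 45000 nM to 250000 nM. The expected step is a 1.7-fold lower number from compound 1 to compound 3 (0.23 log units; within the scatter).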

Compound 3, half-maximal cytotoxic concentration: >= 139000 nM
Compound 3: a limit, no number (the forecaster's own chance of this, stated with the estimate: 15%); middle value at least 1.2-fold (0.10 log units) from the limit.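

In this assay compound 3 is recorded as a limit and not as a number: the limit of >= 139000 nM in this assay, at which 1 of the 3 values shown sits. The step from compound 1 to compound 3 cannot be read, so the 4-nitrophenyl and 3-chlorophenyl groups cannot be placed in order in this test. What the result adds is a second aromatic group at this place, on a saturated chain carbon bound to an aromatic nitrogen: replacing (ethoxycarbonyl)methyl with 4-nitrophenyl goes with an at least 6.4-fold higher number from compound 2 to compound 3 (0.81 log units; beyond the scatter), which runs opposite to the earlier step of an 8.7-fold lower number from compound 1 to compound 2 (0.94 log units; beyond the scatter), so among these three compounds, the one carrying (ethoxycarbonyl)methyl has the lowest number.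

As far as these compounds go, the true number for compound 3 remains open, as does how far it lies from that of compound 1. With only two aromatic groups and one ester-bearing chain shown, these compounds also do not tell whether the gap follows the aromatic ring in general, or where a carboxylic acid, an amine or a longer chain at this place would stand.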